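A few compounds are considered here, and "the series" means these few. Any claim that something is new, unique, unknown or untested is made for them only; others in the source may bear on it.

Measured compounds:

Compound 1 `O=C(Nc1cccc(-n2cc(-c3ccncc3)c(-c3cc(O)cc(Cl)c3)n2)c1)Nc1ccc(Cl)c(C(F)(F)F)c1` gives -32% in a functional assay on SN12C cells (Homo sapiens) for inhibition, read by sulforhodamine B assay, with a stated time of 48 h, tested at 100 uM; a lower number here means a stronger effect, a higher number a weaker effect of the compound at the concentration tested.
Compound 2 `COc1cc(Cl)cc(-c2nn(-c3cccc(NC(=O)Nc4ccc(Cl)c(C(F)(F)F)c4)c3)cc2-c2ccncc2)c1` gives -43% in this assay.
Compound 3 `COc1cc(Cl)cc(-c2nn(-c3cccc(NC(=O)Nc4cc(C(F)(F)F)cc(C(F)(F)F)c4)c3)cc2-c2ccncc2)c1` gives -61% in this assay.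

Among these three numbers compound 2 stands second highest: its nearest neighbour is compound 1, whose number is higher, and the furthest is compound 3, whose number is lower; both gaps are beyond the usual scatter. For the measured compounds named here, the one step recorded between two measured compounds is a number 11 percentage points lower from compound 1 to compound 2 (beyond the scatter), a modest change brought about by a methyl in place of hydrogen on an oxygen on an aromatic ring.

Compound 4 `COc1cc(Cl)cc(-c2nn(-c3cccc(NC(=O)c4cccc(C(F)(F)F)c4)c3)cc2-c2ccncc2)c1` has not yet been measured. It differs from compound 2 by 3-(trifluoromethyl)phenyl in place of (4-chloro-3-(trifluoromethyl)phenyl)amino on a carbonyl carbon. Going by the values given here, no measured pair shows this kind of exchange, so the step from compound 1 to compound 2 does not bear on it, and there is nothing in the numbers to set a direction. The expectation is therefore a step of no clear size beyond the scatter, with wide uncertainty, meaning an estimated a number 18 percentage points higher from compound 2 to compound 4 (beyond the scatter). On that basis compound 4 is expected to give about -25% in this assay, within an estimated range from -55% to 5%.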

Compound 4, a percentage reported as activity, at one concentration (the size of the read-out at that concentration, not a potency): 52%
Estimate against measurement, compound 4: 77 percentage points below; measured number above the stated range.
By their numbers in this assay, from the lowest: compound 3; then compound 2; then compound 1; then compound 4.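

In this assay, the carbonyl carbon proves a far more sensitive place than the oxygen on the aromatic ring: exchanging (4-chloro-3-(trifluoromethyl)phenyl)amino for 3-(trifluoromethyl)phenyl gives a number 95 percentage points higher from compound 2 to compound 4 (beyond the scatter), whereas the methyl in place of hydrogen gave only a number 11 percentage points lower from compound 1 to compound 2 (beyond the scatter). The sign of the read-out changes as well, with compound 2 at -43% and compound 4 at 52%, so compound 4 does not share the negative read-out of compound 1, compound 2 and compound 3. Nothing measured here explains why this exchange has so large an effect.

The exchange removes the amino nitrogen, with its hydrogen-bond donor, and the chlorine together, so the compounds shown leave open which of these losses accounts for the step. A (3-(trifluoromethyl)phenyl)amino group on the carbonyl carbon would keep the nitrogen without the chlorine, and a 4-chloro-3-(trifluoromethyl)phenyl group there would keep the chlorine without the nitrogen, so the two together could separate these contributions.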